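Replacing the Dimethylpiperidine Arm: Cytotoxicity Expected to Ease

The source may report more compounds than this note shows. Statements on the series, on what has been measured and on what is new or still open speak of the compounds shown alone.

Compound 2 `COc1ccc2[nH]c(C(=O)N3CC(=O)N(Cc4ccccc4)[C@@H](N4[C@H](C)CCC[C@@H]4C)C3)cc2c1` has been tested in an ADME assay on Vero cells (Chlorocebus sabaeus) for cytotoxicity, with a stated time of 7 days; a higher number here means that more compound is tolerated, a lower number that less compound is tolerated. In this assay, within the data shown here, compound 2 gives 1400 nM, the only plain number in this small set. Compound 1 `COc1ccc2[nH]c(C(=O)N3CC(=O)N(Cc4ccccc4)[C@@H](Cc4ccccn4)C3)cc2c1` gives > 30000 nM, which is a limit of the assay and not a number. Among the measured compounds shown here, the only measured step, an at least 21-fold lower number from compound 1 to compound 2 (1.33 log units; beyond the scatter), therefore starts from a limit, as the limit of > 30000 nM in this assay, at which 1 of the 2 values shown sits, records, and shows that exchanging the group on that saturated ring carbon can move the reading a long way.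

Compound 3 `COc1ccc2[nH]c(C(=O)N3CC(=O)N(Cc4ccccc4)[C@@H](CN4C(=O)c5ccccc5C4=O)C3)cc2c1` has not yet been measured in this assay. Compared with compound 2 it carries a group of 12 heavy atoms (9 carbon, 1 nitrogen, 2 oxygen; one five-membered non-aromatic ring with 1 hetero atom, one six-membered aromatic ring of carbon only) in place of a group of 8 heavy atoms (7 carbon, 1 nitrogen; one six-membered non-aromatic ring with 1 hetero atom), on a saturated ring carbon. Because an at least 21-fold lower number from compound 1 to compound 2 (1.33 log units; beyond the scatter) showed that an exchange at the same position shifts the number far, a step of comparable size back toward a higher tolerated number is expected for compound 3, while the entering group differs from that of compound 1, so the size stays uncertain. Compound 3 is thus estimated at 10000 nM, with a likely range from 2500 nM to 30000 nM, which would mean an expected step of a 7.1-fold higher number from compound 2 to compound 3 (0.85 log units; beyond the scatter).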

Compound 3, half-maximal cytotoxic concentration: 41000 nM
Estimate against measurement, compound 3: 4.1-fold (0.61 log units) below; measured number above the stated range.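

The a 29-fold higher number from compound 2 to compound 3 (1.47 log units; beyond the scatter) shows that the large change seen earlier at this position was not tied to the pyridine-bearing group of compound 1, since a quite different group also gives a reading far from that of compound 2 in this assay. Among the three compounds, the low number now stands out as belonging to compound 2 alone, the one carrying the 2,6-dimethylpiperidin-1-yl group. Heavy-atom count alone does not track with a lower number here, as the group entering in compound 3 has more heavy atoms than the one it replaces, yet more compound is tolerated. Compound 1 has a limit and not a number, so its step to compound 3 cannot be read, because only one end of that comparison is a plain number: the limit of > 30000 nM in this assay, at which 1 of the 3 values shown sits.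

Compounds 1 and 3 both hold their ring groups on a saturated chain carbon, while compound 2 has its ring nitrogen directly on the saturated ring carbon, so the piperidine and that missing chain carbon cannot be told apart. A 2,6-dimethylpiperidin-1-yl group on such a chain carbon, or a plain piperidin-1-yl group without the two methyl groups, would separate these two differences.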